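The compounds below may be only part of what the source reports. "The series", "measured", "known", "first", "only" and "open" are said of these compounds alone.

- Compound 1 `COc1cc(/C=C2\CN(C)C/C(=C\c3ccc(Br)cc3)C2=O)cc(OC)c1OC`: 15400 nM
- Compound 2 `COc1cc(/C=C2\CN(C)C/C(=C\c3ccc(Cl)c(Cl)c3)C2=O)cc(OC)c1OC`: 18400 nM

In an ADME assay on L02 cells (Homo sapiens) for cytotoxicity, read by MTT assay, with a stated time of 24 h (on this read-out lower numbers stand for stronger inhibition and higher numbers for weaker inhibition), compound 2 gives 18400 nM and compound 1 gives 15400 nM, so the two stand level within the scatter. The next compound is compound 3 `COc1cc(/C=C2\CN(C)C/C(=C\c3cccc([N+](=O)[O-])c3)C2=O)cc(OC)c1OC`. Its structural change from compound 2 is 3-nitrophenyl in place of 3,4-dichlorophenyl on a double-bonded chain carbon bound to a double-bonded ring carbon. The change sits on a double-bonded chain carbon bound to a double-bonded ring carbon.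

Among the measured compounds shown here, only one measured step bears on this position: a 1.2-fold higher number from compound 1 to compound 2 (0.08 log units; within the scatter). That exchange of one substituted phenyl group for another stayed within the scatter. However, no measured compound here carries a nitro group, so this single step is weak evidence and the range must stay wide. In this assay, no step beyond the scatter is expected, and the estimate is a 1.2-fold lower number from compound 2 to compound 3 (0.06 log units; within the scatter). For compound 3, the estimated value is 16000 nM, with an expected range of 7000 nM to 36000 nM.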

Compound 3, half-maximal inhibitory concentration: 13600 nM
Compound 3: middle estimate off by 1.2-fold (0.07 log units), on the high side; the measured number falls inside the stated range.
By their numbers in this assay, from the lowest: compounds 3, 1 and 2 (each within the scatter of the next).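

Among the compounds shown here, the earlier compounds compared only two halogen-bearing phenyl groups, whereas compound 3 carries 3-nitrophenyl, which has no halogen and brings hydrogen-bond acceptors where 3,4-dichlorophenyl has none. Even so, this assay shows a 1.4-fold lower number from compound 2 to compound 3 (0.13 log units; within the scatter) and a 1.1-fold lower number from compound 1 to compound 3 (0.05 log units; within the scatter). On a double-bonded chain carbon bound to a double-bonded ring carbon, this exchange of halogens for a nitro group therefore leaves the read-out level with both earlier compounds, and no measurement shown here offers an explanation for this.

The compounds shown leave open whether a phenyl group carrying an amine or a carboxylic acid would also stay level. They also leave open what a longer chain in place of the substituted phenyl would do.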